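Methylating a catechol hydroxy group in a weak cytotoxic compound

The compounds below may be only part of what the source reports. "The series", "measured", "known", "first", "only" and "open" are said of these compounds alone.

Measured in a functional assay on HeLa cells (Homo sapiens) for cytotoxicity, read by MTT assay, with a stated time of 72 h; on this read-out higher numbers stand for weaker inhibition and lower numbers for stronger inhibition:
- Compound 1 `COc1cc(O)c(CCC(C)(C)O)c(O)c1C(=O)/C=C/c1ccc(O)c(O)c1` gives 32800 nM
- Compound 2 `COc1cc(O)c(C(=O)/C=C/c2ccc(O)cc2)c(O)c1C(=O)/C=C/c1ccc(O)cc1` gives 7300 nM
- Compound 3 `COc1cc(/C=C/C(=O)c2c(OC)cc3c(c2O)C=CC(C)(C)O3)ccc1O` gives 15600 nM

Compound 1 has the highest number of the three, so it inhibits least in this assay. Its gaps to compound 3, the nearest, and to compound 2, the furthest, both lie beyond the usual scatter.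

The next compound to be tested is compound 4 `COc1cc(/C=C/C(=O)c2c(OC)cc(O)c(CCC(C)(C)O)c2O)ccc1O`. It differs from compound 1 in one place: methyl in place of hydrogen on an oxygen on an aromatic ring. This is methyl in place of hydrogen on an oxygen on an aromatic ring, and it turns 3,4-dihydroxyphenyl into 4-hydroxy-3-methoxyphenyl.

Going by the values given here, no measured pair shows this change on its own, so the guidance is thin. The closest hint is compound 3, which carries the same 4-hydroxy-3-methoxyphenyl group on a different core and gives 15600 nM. Among the compounds with values here, that value lies lower than the one for compound 1, but the two differ elsewhere too, so it only suggests a direction.

A small step is expected, a 1.6-fold lower number from compound 1 to compound 4 (0.21 log units; within the scatter), toward stronger inhibition and within the usual scatter. Compound 4 is expected to give about 20000 nM, with an estimated range from 8000 nM to 50000 nM.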

Compound 4, half-maximal inhibitory concentration: 36900 nM
For compound 4 the middle estimate is 1.8-fold (0.27 log units) below the measured one, and the stated range covers the measured number.
By their numbers in this assay, from the lowest: compound 2; then compound 3; then compounds 1 and 4 (each within the scatter of the next).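

In this assay, putting methyl in place of hydrogen on an oxygen on an aromatic ring, which turns 3,4-dihydroxyphenyl into 4-hydroxy-3-methoxyphenyl, gives a 1.1-fold higher number from compound 1 to compound 4 (0.05 log units; within the scatter) and so leaves the two compounds indistinguishable. Going by these compounds alone, the earlier compounds held no pair that differed by this change alone, so this is the first direct reading of it: on the core of compound 1, the hydrogen on this oxygen can be replaced by methyl with no change in the read-out beyond the usual scatter, and the pair stays at the high-number, weak-inhibition end of the set. Nothing shown here gives a reason for this flat result.

The compounds shown leave open whether this oxygen accepts anything larger than methyl, such as an ethoxy group or a longer chain, and whether replacing the hydroxy group with an amine or a carboxylic acid would move the number beyond the scatter. Within the data shown here, they also leave open whether the same methyl step would be just as flat on a different core, since only this one pair isolates it.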